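A few compounds are considered here, and "the series" means these few. Any claim that something is new, unique, unknown or untested is made for them only; others in the source may bear on it.

Measured in a functional assay on HT-29 cells (Homo sapiens) for antiproliferative activity, with a stated time of 48 h; a lower number here means a stronger inhibitor, a higher number a weaker inhibitor:
Compound 1, `O=C(NCCCCl)Nc1ccc(I)cc1`: 90000 nM
Compound 2, `CCCCCc1cccc(NC(=O)NCCCCl)c1`: 28000 nM

Two compounds share a urea core and differ only in the substituent on the aromatic ring. In this assay compound 2 gives the lower of the two numbers, and its gap to compound 1 lies beyond the usual scatter of repeated measurements, so compound 2 is the stronger of the pair on the numbers shown.

The unmeasured compound 3, `CCCCC(O)c1cccc(NC(=O)NCCCCl)c1`, is built from compound 2 by a single change: hydroxy in place of hydrogen on a saturated chain carbon bound to an aromatic carbon and a saturated chain carbon. The pentyl chain stays, and only one of its hydrogens is replaced by a hydroxy group.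

Going by the values given here, no measured pair here shows the effect of such a change, so no step size can be read from the data. Going from compound 2 to compound 3, the expected step is a 1.3-fold higher number from compound 2 to compound 3 (0.10 log units; within the scatter), which is meant as no change beyond the scatter in this assay. Compound 3 is therefore estimated at 35000 nM, with a range from 12000 nM to 100000 nM.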

Compound 3, half-maximal inhibitory concentration: 19000 nM
The estimate for compound 3 lay 1.8-fold (0.27 log units) above the measured number; low and high end bracket the measured number.
By their numbers in this assay, from the lowest: compounds 3 and 2 (each within the scatter of the next); then compound 1.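

Putting a hydroxy group on the pentyl chain, at the saturated chain carbon bound to an aromatic carbon and a saturated chain carbon, gives in this assay a 1.5-fold lower number from compound 2 to compound 3 (0.17 log units; within the scatter) and so leaves pentyl and 1-hydroxypentyl indistinguishable here. Going by these compounds alone, the earlier compounds contained no pair differing at this chain carbon, so this is the first direct reading of the position: it accepts a hydroxy group, with its hydrogen-bond donor and acceptor, without a change beyond the scatter. Nothing available here offers a reason for this result.

Within the data shown here, the pair tests only one group at one carbon, so it remains open whether a ketone or an amine on that same carbon, or a hydroxy group further out along the pentyl chain, would also leave the number unchanged. As far as these compounds go, it is equally open whether a hydroxy group at this carbon would be accepted on a shorter chain such as propyl or on a longer chain such as octyl, since only the pentyl chain has been read with and without it.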